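From 4-methylpiperazin-1-yl to 4-ethylpiperazin-1-yl

The source may hold more compounds than are shown below. What is called first, only, known or untested is meant among the compounds shown, and "the series" means these compounds.

In a functional assay on SNU-423 cells (Homo sapiens) for antiproliferative activity (on this read-out higher numbers stand for weaker inhibition and lower numbers for stronger inhibition), compound 1 `COc1cc(N(CCCSC(=S)N2CCN(C(C)=O)CC2)S(=O)(=O)c2cccc3cccnc23)cc(OC)c1OC` gives 700 nM, and compound 2 `COc1cc(N(CCCSC(=S)N2CCN(C)CC2)S(=O)(=O)c2cccc3cccnc23)cc(OC)c1OC` gives 700 nM, level with compound 1. Compound 3 `CCN1CCN(C(=S)SCCCN(c2cc(OC)c(OC)c(OC)c2)S(=O)(=O)c2cccc3cccnc23)CC1` differs from compound 2 by methyl in place of hydrogen on a saturated chain carbon bound to an amine nitrogen in a ring, with methyl in place of hydrogen on a saturated chain carbon bound to an amine nitrogen in a ring. Going by the values given here, the only measured step bearing on this, no change at the digits printed from compound 1 to compound 2 (within the scatter), changed the group on that ring nitrogen and stayed within the scatter. The expected step of no change at the digits printed from compound 2 to compound 3 (within the scatter) is likewise none beyond the scatter. The estimate for compound 3 in this assay is 700 nM, with an expected range of 300 nM to 1600 nM.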

Compound 3, half-maximal inhibitory concentration: 700 nM
The estimate for compound 3 equals the measured number at the digits printed; the measured number falls inside the stated range.
By their numbers in this assay, from the lowest: compounds 1, 2 and 3 (each within the scatter of the next).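

In this assay, the step from methyl to ethyl gives no change at the digits printed from compound 2 to compound 3 (within the scatter) and shows that this one-carbon extension on the ring nitrogen leaves the read-out within the scatter. The step from acetyl to ethyl gives no change at the digits printed from compound 1 to compound 3 (within the scatter) and so extends the flat picture to all three groups shown at this position. Nothing available explains why these groups read alike. On these data alone, whether a longer chain such as butyl, or a carboxylic acid carried on that ring nitrogen, would stay level remains open.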